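Purine series with chloromethylbenzyl groups: next dichloro analogue

The compounds below may be only part of what the source reports. "The series", "measured", "known", "first", "only" and "open" are said of these compounds alone.

Three compounds have numbers in a functional assay on COLO 205 cells (Homo sapiens) for cytotoxicity, read by sulforhodamine B assay, with a stated time of 48 h (on this read-out lower numbers stand for stronger inhibition of growth and higher numbers for weaker inhibition of growth), so far. Compound 1 `ClCc1cccc(Cn2cnc3c(Cl)nc(Cl)nc32)c1` gives 2230 nM, compound 3 `ClCc1ccc(Cn2cnc3c(Cl)nc(Cl)nc32)cc1` gives 3470 nM, and compound 2 `ClCc1ccccc1Cn1cnc2ncnc(Cl)c21` gives 4360 nM. Compound 2 stands at the highest of the three numbers, but its gaps to compound 3 and to compound 1 both fall within the usual scatter, so no order among the three can be read from these numbers.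

Compound 4 `ClCc1ccccc1Cn1cnc2nc(Cl)nc(Cl)c21` differs from compound 2 by one change: chloro in place of hydrogen on an aromatic carbon. Going by the values given here, no measured pair in this set shows the same change on its own, so the size of the step is not known from the data. Compound 1 and compound 3 carry the same two chloro groups on the core as compound 4 and sit at numbers close to compound 2, which points to a small step, if any. The step from compound 2 to compound 4 is expected to be a 1.5-fold lower number from compound 2 to compound 4 (0.16 log units; within the scatter), within the scatter. For compound 4 in this assay the estimate is 3000 nM, with a range from 1200 nM to 7500 nM.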

Compound 4, concentration for 50% growth inhibition: 350 nM
Compound 4: middle estimate off by 8.6-fold (0.93 log units), on the high side, outside the stated range (below it).
By their numbers in this assay, from the lowest: compound 4; then compounds 1, 3 and 2 (each within the scatter of the next).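

Going by these compounds alone, this is the first pair that differs in one place, and it shows that the carbon between two ring nitrogen atoms is far from silent in this assay: chloro in place of hydrogen there gives a 12-fold lower number from compound 2 to compound 4 (1.10 log units; beyond the scatter) and moves compound 4 clear of the other three compounds. Within the data shown here, the three earlier numbers lay within the scatter of each other and could not show this, as no two of those compounds differed in one place. Nothing at hand bears on why this step is so large.

On these data alone, whether the step depends on chloro itself stays open, as an amine, a methoxy group or a methyl group on the same carbon would show. Also open, as far as these compounds go, is whether the same change gives a step of this size with the chloromethyl group placed elsewhere on the benzyl ring.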